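Methyl in place of nitro in an alpha-2C agonist series

This account rests on a few compounds, and the source may have more. Where it says the series, first, only, none or still open, it means among the compounds named here.

Three analogues sharing the same core have been measured in a functional assay on CHO cells for agonist activity at Alpha-2C adrenergic receptor (Homo sapiens); on this read-out higher numbers stand for larger maximal responses and lower numbers for smaller maximal responses. Compound 1 `CC(Oc1ccccc1-c1ccccc1[N+](=O)[O-])C1=NCCN1` reaches only the limit of the assay, < 0.3, and no number is reported for it. Compound 3 `CC(Sc1ccccc1-c1ccccc1)C1=NCCN1` likewise sits at a limit, < 0.3. Compound 2 `CC(Nc1ccccc1-c1ccccc1)C1=NCCN1`, by contrast, gives a numerical value in this assay of 0.7. Compound 1 therefore stands at the lower end of what has been seen so far, sharing the limit of < 0.3 in this assay, at which 2 of the 3 values shown sit, with compound 3, while compound 2 stands clearly apart from both.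

Compound 4 `Cc1ccccc1-c1ccccc1OC(C)C1=NCCN1` has not yet been measured. It differs from compound 1 by methyl in place of nitro on an aromatic carbon. Among the measured compounds shown here, no step between measured compounds resembles this change, so the expected size of the step is uncertain; a modest rise in this assay, possibly beyond the scatter but possibly not, is what one might expect, with the step a number at least 0.10 higher from compound 1 to compound 4 (that floor lies within the scatter) estimated accordingly. For compound 4 the estimated intrinsic activity is 0.4, with a range from 0.15 to 0.7.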

Compound 4, intrinsic activity: the largest response reached, as a fraction of the reference agonist's: 0.45
Compound 4: middle estimate off by 0.050, on the low side, within the range that was stated.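

Methyl in place of nitro, on an aromatic carbon ortho to a large group, gives a step in this assay of a number at least 0.15 higher from compound 1 to compound 4 (beyond the scatter). Among the compounds shown here, this is the first step that can be read between two compounds differing in one place, and it shows that what sits at this position matters to the maximal response. Compound 1 remains at a limit and not a number, so the step is a floor and its full size stays unknown: the limit of < 0.3 in this assay, at which 2 of the 4 values shown sit.

The compounds shown leave open whether a chlorine atom, a methoxy group or a plain hydrogen at this position would give a response like that of compound 4 or stay at a limit like compound 1. Nor do they tell whether an ethyl group or a longer chain in that place would raise the response further or lose it.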